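The compounds below may be only part of what the source reports. "The series", "measured", "known", "first", "only" and "open" are said of these compounds alone.

Series notes, the group on the saturated chain carbon bound to an aromatic carbon and a saturated chain carbon.

Three compounds of the shared core have numbers in an assay on CHO cells for displacement of a labelled ligand from prostaglandin E2 receptor EP3 subtype (Homo sapiens), read by radioligand binding; a lower number here means a stronger inhibitor, a higher number a weaker inhibitor. Compound 1 `CC(C)C(Cc1ncc[nH]1)c1ccc(-c2ccc3cccc(F)c3c2)[nH]c1=O` gives 11 nM. Compound 2 `CC(C)C(c1ccc(-c2ccc3cccc(F)c3c2)[nH]c1=O)N1CCCCC1=O` gives 6.4 nM. Compound 3 `CC(C)C(c1nnc[nH]1)c1ccc(-c2ccc3cccc(F)c3c2)[nH]c1=O` gives 12 nM, the largest of the three numbers, yet a 1.1-fold higher number from compound 1 to compound 3 (0.04 log units; within the scatter) and a 1.9-fold higher number from compound 2 to compound 3 (0.27 log units; within the scatter), so the three compounds sit together within the usual spread of this assay, and none can be set apart from the others on these numbers.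

Compound 4 `CC(C)C(Cc1nnn[nH]1)c1ccc(-c2ccc3cccc(F)c3c2)[nH]c1=O` has not been measured. Its structure differs from compound 3 in one place: (1H-tetrazol-5-yl)methyl in place of 4H-1,2,4-triazol-3-yl on a saturated chain carbon bound to an aromatic carbon and a saturated chain carbon. The two steps that bear on this position are the swaps of the same group in compound 1 and compound 2 against compound 3. Both were small: a 1.1-fold higher number from compound 1 to compound 3 (0.04 log units; within the scatter) and a 1.9-fold higher number from compound 2 to compound 3 (0.27 log units; within the scatter), and also a 1.7-fold lower number from compound 1 to compound 2 (0.24 log units; within the scatter). Every change tried at this carbon, whether a methyl-linked azole, a direct azole or a lactam, has stayed within the scatter, so no step beyond the scatter in this assay is expected for compound 4 in either direction, no change at the digits printed from compound 3 to compound 4 (within the scatter). The estimate for compound 4 is therefore 12 nM, with a range from 5 nM to 30 nM.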

Compound 4, inhibition constant: 34 nM
Compound 4: the middle estimate sits 2.8-fold (0.45 log units) below what was measured; the whole stated range lies below it.
By their numbers in this assay, from the lowest: compounds 2, 1 and 3 (each within the scatter of the next); then compound 4.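

In this assay this position now shows a real response, as the steps of a 2.8-fold higher number from compound 3 to compound 4 (0.45 log units; beyond the scatter) and a 5.3-fold higher number from compound 2 to compound 4 (0.73 log units; beyond the scatter) and a 3.1-fold higher number from compound 1 to compound 4 (0.49 log units; beyond the scatter) all lie beyond the scatter, while the three earlier groups could not be told apart. Among the compounds shown here, the step from compound 1 is the most telling of these, as the methyl link on the saturated chain carbon stays in place and only the ring changes, from 1H-imidazol-2-yl to 1H-tetrazol-5-yl, so a methyl-linked azole does not by itself keep the number within the range of the earlier compounds. Nothing available here offers an explanation for this step, so the result stands as an observation only.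

As far as these compounds go, it remains open whether the shift follows the ring alone or the ring together with its link, a question that 1H-tetrazol-5-yl placed directly on the saturated chain carbon would address in a comparison with compound 3 and compound 4. Also open, from the compounds shown here alone, is how a carboxylic acid on the same methyl link, or 1H-tetrazol-5-yl on a longer chain, would read against compound 4 in this assay on this shared core.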